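The compounds below may be only part of what the source reports. "The series", "measured", "known", "first", "only" and "open" are said of these compounds alone.

Compound 1 `CCN(CC)CCCCn1c(N)c(-c2nc3ccccc3[nH]2)c2nc(C#N)c(C#N)nc21` and compound 2 `CN(C)CCCn1c(N)c(-c2nc3cc(Cl)ccc3[nH]2)c2nc(C#N)c(C#N)nc21` share one core and were both tested in a functional assay on A549 cells (Homo sapiens) for antiproliferative activity, read by MTT assay, with a stated time of 48 h; a higher number here means a weaker inhibitor, a lower number a stronger inhibitor. In this assay compound 1 gives 5750 nM. Compound 2 returns in this assay no number but a limit of the assay, > 50000 nM, and the limit of > 50000 nM in this assay, at which 1 of the 2 values shown sits, records where that limit stands. Within the data shown here, compound 1 and compound 2 differ in more than one place, so no single step joins them; their two results show only that compound 1 gives a number and compound 2 does not.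

Compound 3 `CCN(CC)CCCCn1c(N)c(-c2nc3cc(Cl)ccc3[nH]2)c2nc(C#N)c(C#N)nc21` has not yet been measured in this assay. It differs from compound 2 by (diethylamino)methyl in place of dimethylamino on a saturated chain carbon, three bonds along the chain from an aromatic nitrogen. Among the measured compounds shown here, compound 1 already bears the 4-(diethylamino)butyl chain, and in this assay compound 1 gives 5750 nM, the only number in hand. For the measured compounds named here, no measured pair isolates this change, so the expectation rests on that alone. The step that the estimate means, an at least 2.5-fold lower number from compound 2 to compound 3 (0.39 log units; beyond the scatter), is expected to run toward a stronger inhibitor, of modest size and with wide uncertainty. Compound 3 is therefore expected to come in near 20000 nM, within a range from 5000 nM to 80000 nM.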

Compound 3, half-maximal inhibitory concentration: 2270 nM
For compound 3 the middle estimate is 8.8-fold (0.95 log units) above the measured one; measured number outside the range, below it.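

In this assay, replacing the 3-(dimethylamino)propyl chain with the 4-(diethylamino)butyl chain gives the first step read at this position, an at least 22-fold lower number from compound 2 to compound 3 (1.34 log units; beyond the scatter), and it takes the series from a limit to a number. With the 4-(diethylamino)butyl chain held fixed, the step for chloro in place of hydrogen on an aromatic carbon is also beyond the scatter, a 2.5-fold lower number from compound 1 to compound 3 (0.40 log units; beyond the scatter), so the chloro group does not by itself go with a loss of activity in this pair. The result for compound 2 is a limit of the assay and not a number, so the chain step has a lower bound but no fixed size: the limit of > 50000 nM in this assay, at which 1 of the 3 values shown sits.

The chain change alters the chain length and the groups on the amine together, so the compounds shown cannot separate the two, and a 3-(diethylamino)propyl or a 4-(dimethylamino)butyl chain would be needed to do so. They also leave open how a cyclic amine such as piperidine at the chain end, or a fluoro or methoxy group in place of the chloro, would read in this assay.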